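The source may report more compounds than this note shows. Statements on the series, on what has been measured and on what is new or still open speak of the compounds shown alone.

Among the measured compounds shown here, compound 2 `CC1(C)Cc2c(sc(NC(=O)C3CCNC3=O)c2C(N)=O)C(C)(C)O1` gives 101 nM in an assay on cells for positive allosteric modulation of Cystic fibrosis transmembrane conductance regulator variant F508del (Homo sapiens), with stated times of 10 min and 7 s, in the presence of a further agent that is not named here (on this read-out lower numbers stand for an effect already at smaller amounts and higher numbers for an effect only at larger amounts of compound), which is the lower of the two numbers measured so far. Its nearest neighbour is compound 1 `CC1(C)Cc2c(sc(NC(=O)c3cn[nH]c3)c2C(N)=O)C(C)(C)O1`, which in this assay gives 125 nM; the step of a 1.2-fold lower number from compound 1 to compound 2 (0.09 log units; within the scatter), so the two compounds cannot be told apart on this read-out. Compound 3 `CC1(C)Cc2c(sc(NC(=O)C3CNC(=O)C3)c2C(N)=O)C(C)(C)O1` is the next compound and differs from compound 2 only in that (5-oxopyrrolidin-3-yl in place of 2-oxopyrrolidin-3-yl on a carbonyl carbon). For the measured compounds named here, the single measured step bears on it only loosely: it exchanged the whole group on that carbonyl carbon, whereas here the same atoms are merely rearranged within the ring, and that step stayed within the scatter. Compound 3 is therefore expected to show no change beyond the scatter, that is a 1.1-fold higher number from compound 2 to compound 3 (0.04 log units; within the scatter). Compound 3 is estimated at 110 nM, with a plausible range from 50 nM to 250 nM.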

Compound 3, half-maximal effective concentration: > 10000 nM
Compound 3: only a limit was reported; the forecaster's own chance of this, stated with the estimate: 5%; at least 90-fold (1.95 log units) between middle value and limit.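

In this assay compound 3 gives only a limit and not a number: the limit of > 10000 nM in this assay, at which 1 of the 3 values shown sits. With the same atoms joined differently and the same counts of donors and acceptors, the change from 2-oxopyrrolidin-3-yl to 5-oxopyrrolidin-3-yl on this carbonyl carbon gives an at least 99-fold higher number from compound 2 to compound 3 (1.99 log units; beyond the scatter) and so shows that the read-out here depends on how the ring is joined, not only on which atoms it holds. The exchange of 1H-pyrazol-4-yl for 5-oxopyrrolidin-3-yl gives an at least 80-fold higher number from compound 1 to compound 3 (1.90 log units; beyond the scatter) and so shows that this place does not accept every group, which the earlier exchange, within the scatter, had not revealed.

The compounds shown do not tell why the two arrangements part so far, or how far compound 3 lies past its limit. On these data alone, whether an open-chain amide or a carboxylic acid on the same carbonyl carbon would retain the effect also stays open.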